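The source may hold more compounds than are shown below. What is called first, only, known or untested is meant among the compounds shown, and "the series" means these compounds.

Of the compounds shown here, three that share one core have so far been tested in a physicochemical assay for solubility, in phosphate buffer, measured as kinetic solubility, at pH 7.4; a higher number here means a more soluble compound, a lower number a less soluble compound. Compound 1, `Cc1ccccc1-c1nc(CN2CCC(C(=O)NCCCN3CCC(C(C)C)CC3)CC2)c(C)o1`, gives > 71 ug/mL, which is a limit and not a number. Compound 2, `Cc1ccccc1-c1nc(CN2CCC(C(=O)NCCCN3CCC(C)CC3)CC2)c(C)o1`, gives > 67 ug/mL, again a limit. Compound 3, `Cc1ccccc1-c1nc(CN2CCC(C(=O)NCCCN3CCCC(C(C)C)C3)CC2)c(C)o1`, gives > 71 ug/mL, also a limit, so it has no exact place on the scale.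

Compound 4, `Cc1ccccc1-c1nc(CN2CCC(C(=O)NCCCCN3C[C@H](C)C[C@H](C)C3)CC2)c(C)o1`, has not yet been measured. It differs from compound 3 as follows: a group of 9 heavy atoms (8 carbon, 1 nitrogen; one six-membered non-aromatic ring with 1 hetero atom) in place of a group of 9 heavy atoms (8 carbon, 1 nitrogen; one six-membered non-aromatic ring with 1 hetero atom), on a saturated chain carbon, three bonds along the chain from an amide-type nitrogen. The two have the same atoms, joined differently, with the (3,5-dimethylpiperidin-1-yl)methyl group entering on a saturated chain carbon, three bonds along the chain from an amide-type nitrogen.

Within the data shown here, three measured steps bear on this change: a step that the two limits leave unreadable from compound 1 to compound 2, a step that the two limits leave unreadable from compound 1 to compound 3 and a step that the two limits leave unreadable from compound 2 to compound 3. None of them has a readable size, so they offer neither a size nor a direction to carry over. The expectation therefore starts from compound 3 and its limit of > 71 ug/mL. No shift beyond the usual scatter is expected in this assay, and the estimated change is a number no higher from compound 3 to compound 4 (the limit leaves the size open). Compound 4 is estimated at 71 ug/mL, with an expected range from 50 ug/mL to 80 ug/mL.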

Compound 4, solubility: > 71 ug/mL
Compound 4: a limit, no number; the forecaster's own chance of this, stated with the estimate: 85%; the middle value sits exactly at the limit.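

In this assay compound 4 gives > 71 ug/mL, which is a limit and not a number. Compound 1, compound 2 and compound 3 also have only limits, so none of the steps from them to compound 4 can be read. The compounds shown leave open where any of the four truly lies on this scale, and whether changing the group moves it at all.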